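This account rests on a few compounds, and the source may have more. Where it says the series, first, only, none or still open, it means among the compounds named here.

In a functional assay on HeLa cells (Homo sapiens) for cytotoxicity, read by ELISA, with a stated time of 2 days (on this read-out higher numbers stand for weaker inhibition and lower numbers for stronger inhibition), compound 1 (`Oc1ccccc1-c1cc(-c2ccccc2)cc(-c2ccccc2O)n1`) gives 14800 nM and compound 2 (`Oc1cccc(-c2cc(-c3ccccc3)cc(-c3ccccc3)n2)c1`) gives 16100 nM. Among the compounds with values here, these two values lie within the scatter of each other, so compound 2 stands level with compound 1 on the numbers so far. Compound 3 (`Oc1cccc(-c2cc(-c3ccccc3)cc(-c3cccs3)n2)c1`) differs from compound 2 in one place, with thiophen-2-yl in place of phenyl on an aromatic carbon, next to the ring nitrogen (thiophen-2-yl in place of phenyl on an aromatic carbon). Within the data shown here, no measured pair shows what such an exchange does, so the data give no direct guide to its size. The expectation therefore rests on compound 2 at 16100 nM, and no shift beyond the scatter is expected in this assay, in either direction. The estimate corresponds to a 1.2-fold lower number from compound 2 to compound 3 (0.06 log units; within the scatter), an expected step within the scatter. For compound 3 the estimated value is 14000 nM, with an expected range from 6000 nM to 32000 nM.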

Compound 3, half-maximal inhibitory concentration: 17000 nM
Beside the measured number, compound 3's estimate is 1.2-fold (0.08 log units) below it; low and high end bracket the measured number.
By their numbers in this assay, from the lowest: compounds 1, 2 and 3 (each within the scatter of the next).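

The exchange of phenyl for thiophen-2-yl on the aromatic carbon next to the ring nitrogen gives a 1.1-fold higher number from compound 2 to compound 3 (0.02 log units; within the scatter) in this assay and so lies within the scatter. This is the only pair shown that differs in one place, and it shows that at this position a five-membered aromatic ring holding sulfur leaves compound 3 level with compound 2 on this read-out. The data shown offer no measurement that could account for this result.

From the compounds shown here alone, it remains open whether an amine, a carboxylic acid or a longer alkyl chain at this same carbon would give a step beyond the scatter. Going by these compounds, it is equally open whether thiophen-3-yl or furan-2-yl would stand level with thiophen-2-yl there.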